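The source may report more compounds than this note shows. Statements on the series, on what has been measured and on what is new or still open speak of the compounds shown alone.

Cytotoxicity notes on the series. In a functional assay on cells (Homo sapiens) for cytotoxicity (a higher number here means that more compound is tolerated, a lower number that less compound is tolerated), compound 3 `O=C1N(CCCCCCCOc2ccc(C(F)(F)F)cc2)CCN1c1ccncc1` gives 6250 nM. Compound 2 `O=C1N(CCCCCOc2ccc(C(F)(F)F)cc2)CCN1c1ccncc1` gives 12500 nM in this assay, and the two numbers sit within the usual scatter of each other, so no difference between compound 2 and compound 3 can be read from them. Compound 1 `O=C1N(CCCCCCOc2ccc(Br)cc2)CCN1c1ccncc1` reaches only a limit of the assay, > 25000 nM, and reports no number; this is the case described as the limit of > 25000 nM in this assay, at which 1 of the 3 values shown sits. Among the measured compounds shown here, no step between two measured compounds that differ in a single place is available, so nothing about the effect of one change at a time can be taken from the measured set.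

Compound 4 `O=C1N(CCCCCCCOc2ccc(Cl)cc2)CCN1c1ccncc1` is the next one to be measured in this assay. It differs from compound 3 in one place: chloro in place of trifluoromethyl on an aromatic carbon. For the measured compounds named here, as no measured pair shows what this change does to tolerated concentration, the expectation rests on the number for compound 3 and on the general spread of the measured values. For compound 4 a step of a 1.4-fold higher number from compound 3 to compound 4 (0.16 log units; within the scatter) is expected, that is, a number not clearly outside the scatter around compound 3. Compound 4 is therefore estimated at 9000 nM, with a range from 3500 nM to 25000 nM.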

Compound 4, half-maximal cytotoxic concentration: > 25000 nM
Compound 4 ended at the assay's limit; the forecaster's own chance of this, stated with the estimate: 25%; middle value at least 2.7-fold (0.44 log units) from the limit.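

The series now has its first readable step at a single place: going from 4-(trifluoromethyl)phenyl to 4-chlorophenyl, with the rest of the structure unchanged, gives in this assay an at least 4.0-fold higher number from compound 3 to compound 4 (0.60 log units; beyond the scatter), so the group at this position of the aromatic ring does bear on the tolerated concentration. In this assay compound 4 gives > 25000 nM, which is a limit and not a number, so this step has a minimum size but no measured size. The step between compound 1 and compound 4 cannot be read, and the limit is now shared by two compounds: the limit of > 25000 nM in this assay, at which 2 of the 4 values shown sit.

As far as these compounds go, it stays open whether this step belongs to chloro in particular or would also appear with another group in the same place, such as a methoxy group or a nitrile, and a compound with a measured number in place of a limit would be needed to size it. From the compounds shown here alone, it also stays open whether the same change gives a step of this kind on a shorter chain, since compound 2 has no partner that differs from it in this group alone.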